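Replacing the sulfonyl aryl group of compound 2

This account rests on a few compounds, and the source may have more. Where it says the series, first, only, none or still open, it means among the compounds named here.

Within the data shown here, in a functional assay on RS4-11 cells (Homo sapiens) for inhibition, read by CCK-8 assay, with a stated time of 48 h, tested at 20 uM (on this read-out lower numbers stand for less inhibition of growth and higher numbers for more inhibition of growth at the one concentration tested), compound 1 (`N#C/C(=C\c1ccccc1OS(=O)(=O)c1ccc(F)cc1)C(=O)Nc1nnc(Cc2ccc(F)cc2)s1`) gives 59% and compound 2 (`N#C/C(=C\c1ccccc1OS(=O)(=O)c1ccccc1[N+](=O)[O-])C(=O)Nc1nnc(Cc2cccc(F)c2)s1`) gives 68% so compound 2 stands within the scatter of the only other measured compound. Compound 3 (`N#C/C(=C\c1ccccc1OS(=O)(=O)c1ccc(F)cc1)C(=O)Nc1nnc(Cc2cccc(F)c2)s1`) has not yet been measured. It has 4-fluorophenyl in place of 2-nitrophenyl on a sulfonyl sulfur and shares that group with compound 1. Among the measured compounds shown here, compounds 1 and 2 differ in more than one place, so no measured step isolates this change. Even so, compound 1 carries the incoming group and gives 59% within the scatter of compound 2, and this supports expecting no change beyond the scatter. The expected a number 5 percentage points lower from compound 2 to compound 3 (within the scatter) is estimated to remain within the scatter. For compound 3 the estimated value is 63% with an expected range from 50% to 76% in this test.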

Compound 3, percent growth inhibition at one concentration: 72%
Compound 3: middle estimate off by 9 percentage points, on the low side; the range from low to high includes it.
By their numbers in this assay, from the lowest: compounds 1, 2 and 3 (each within the scatter of the next, the first and the last beyond it).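

In this assay, the change from 2-nitrophenyl to 4-fluorophenyl on the sulfonyl sulfur, now isolated as a single step, gives a number 4 percentage points higher from compound 2 to compound 3 (within the scatter), so the two aryl groups cannot be told apart at this position, although the entering group is smaller by the count of heavy atoms. The new compound also isolates a second change, 3-fluorophenyl in place of 4-fluorophenyl on a saturated chain carbon bound to an aromatic carbon, which gives a number 13 percentage points higher from compound 1 to compound 3 (beyond the scatter), a modest step with the sulfonyl group held constant. Nothing available accounts for either step.

The compounds shown leave open whether a group without an aromatic ring, such as methyl or a morpholine, would hold the growth inhibition on the sulfonyl sulfur. They also leave open whether an unsubstituted phenyl on the saturated chain carbon would do so.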